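Lengthening the Ester Chain: From Compound 3 to Compound 4

The source may hold more compounds than are shown below. What is called first, only, known or untested is meant among the compounds shown, and "the series" means these compounds.

Three measured compounds share one core and differ only in the length of a saturated chain attached through an oxygen next to a carbonyl group. Compound 1 `CCCOC(=O)CCC(=O)N1CCN(CCCOc2cc3c(Nc4ccc(F)c(Cl)c4)ncnc3cc2OC)CC1` gives, in a functional assay on A549 cells (Homo sapiens) for cytotoxicity, read by MTT assay, with a stated time of 24 h, tested at 20 uM (a higher number here means a weaker effect of the compound at the concentration tested, a lower number a stronger effect), a reading of 87%. Compound 2 `CCCCOC(=O)CCC(=O)N1CCN(CCCOc2cc3c(Nc4ccc(F)c(Cl)c4)ncnc3cc2OC)CC1` gives in this assay 86%, and compound 3 `CCCCCCCOC(=O)CCC(=O)N1CCN(CCCOc2cc3c(Nc4ccc(F)c(Cl)c4)ncnc3cc2OC)CC1` gives in this assay 79.9%. The steps between them are small: a number 1 percentage points lower from compound 1 to compound 2 (within the scatter), a number 7.1 percentage points lower from compound 1 to compound 3 (within the scatter) and a number 6.1 percentage points lower from compound 2 to compound 3 (within the scatter). Compound 3 thus holds the lowest of the three numbers, but its distance to compound 2 and to compound 1 each lies within the usual scatter, so no real ordering can be read from these three values.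

Compound 4 `CCCCCCCCCCCOC(=O)CCC(=O)N1CCN(CCCOc2cc3c(Nc4ccc(F)c(Cl)c4)ncnc3cc2OC)CC1` continues the same series: butyl in place of hydrogen on a saturated chain carbon, seven bonds along the chain from an oxygen next to a carbonyl group. Among the measured compounds shown here, the steps that bear on this change are those from compound 1 to compound 3 and from compound 2 to compound 3, where butyl or propyl entered on the chain and the reading moved slightly downward without leaving the scatter. A similar, modest movement is therefore expected here, a number 5.9 percentage points lower from compound 3 to compound 4 (within the scatter), most likely again within the scatter. Compound 4 is estimated to give 74% in this assay, with a plausible range from 58% to 88%.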

Compound 4, a percentage reported as activity, at one concentration (the size of the read-out at that concentration, not a potency): 85.2%
For compound 4 the middle estimate is 11.2 percentage points below the measured one; low and high end bracket the measured number.
By their numbers in this assay, from the lowest: compounds 3, 4, 2 and 1 (each within the scatter of the next).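

Among the compounds shown here, putting butyl on a saturated chain carbon, seven bonds along the chain from an oxygen next to a carbonyl group, gives in this assay a number 5.3 percentage points higher from compound 3 to compound 4 (within the scatter) and so does not carry on the slight downward drift of the earlier steps, although neither direction means anything inside the scatter. The comparisons with the shorter chains read the same way, with a number 0.8 percentage points lower from compound 2 to compound 4 (within the scatter) and a number 1.8 percentage points lower from compound 1 to compound 4 (within the scatter) showing that even the long chain of compound 4 leaves its reading indistinguishable from those of the other three, so chain length at this position has no detectable effect across these four compounds in this assay at the one concentration tested. No supporting evidence is available to explain the reading of compound 4.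

The compounds shown leave open whether a still longer chain, or an amine or a carboxylic acid at the end of the chain, would produce a reading beyond the scatter. As far as these compounds go, a single concentration also gives no potency, so any difference between these four compounds that this read-out cannot resolve remains unknown.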